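Methyl position on the sulfonyl ring: inhibition in this assay

The source may hold more compounds than are shown below. What is called first, only, known or untested is meant among the compounds shown, and "the series" means these compounds.

Measured compounds:
compound 1 `O=C(Nc1cccc(/C=C/C(=O)c2nc3ccccc3[nH]2)c1)c1cccc(Cl)c1` gives 19.5%
compound 2 `Cc1cccc(S(=O)(=O)Nc2cccc(/C=C/C(=O)c3nc4ccccc4[nH]3)c2)c1` gives 50.1%

In an assay on isolated protein for inhibition of cathepsin S (Homo sapiens), read by fluorescence, with stated times of 15 min and 30 min, tested at 5 uM (on this read-out lower numbers stand for less inhibition and higher numbers for more inhibition at the one concentration tested (going by the name of the read-out)), compound 2 stands highest of the two numbers; its nearest neighbour is compound 1, which gives a lower value, and the step of a number 30.6 percentage points higher from compound 1 to compound 2 (beyond the scatter) lies beyond the scatter. Compound 3 `Cc1ccc(S(=O)(=O)Nc2cccc(/C=C/C(=O)c3nc4ccccc4[nH]3)c2)cc1` has not yet been measured. It differs from compound 2 in a single place: 4-methylphenyl in place of 3-methylphenyl on a sulfonyl sulfur. Among the measured compounds shown here, the only measured step, a number 30.6 percentage points higher from compound 1 to compound 2 (beyond the scatter), changes both the group on the nitrogen and the aryl substituent at once, so no measured pair shows the effect of moving a methyl group from one position of the phenyl ring to another on the sulfonyl sulfur. With nothing in the data bearing directly on this change, the expected step of a number 2.1 percentage points lower from compound 2 to compound 3 (within the scatter) is none beyond the scatter. Compound 3 is therefore estimated to give 48% in this assay, with a range from 30% to 66%.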

Compound 3, a percentage reported as inhibition, at one concentration (the size of the read-out at that concentration, not a potency): 22%
Estimate against measurement, compound 3: 26 percentage points above; measured number below the stated range.
By their numbers in this assay, from the lowest: compounds 1 and 3 (each within the scatter of the next); then compound 2.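

In this assay, moving the methyl alone gives a number 28.1 percentage points lower from compound 2 to compound 3 (beyond the scatter), so on the sulfonyl sulfur 3-methylphenyl and 4-methylphenyl are not interchangeable, although the two groups have the same atoms. The replacement of (3-chlorophenyl)carbonyl on the nitrogen therefore has no single outcome: with 3-methylphenyl it gives a number 30.6 percentage points higher from compound 1 to compound 2 (beyond the scatter), whereas with 4-methylphenyl it gives a number 2.5 percentage points higher from compound 1 to compound 3 (within the scatter), so the earlier gain cannot be credited to the sulfonyl link alone. No available evidence accounts for the difference between the two methyl positions.

The compounds shown leave open how a methoxy group, a chlorine or an amine in place of the methyl on this ring would read out. They also leave open whether a plain phenyl on the sulfonyl sulfur would stand nearer compound 2 or compound 3.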